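Swapping the pendant aryl on the shared core

A few compounds are considered here, and "the series" means these few. Any claim that something is new, unique, unknown or untested is made for them only; others in the source may bear on it.

Three analogues of one core have been run in an assay on CHO cells for antagonist activity at transient receptor potential cation channel subfamily V member 1 (Homo sapiens), read by FLIPR; a lower number here means a stronger inhibitor, a higher number a weaker inhibitor. Compound 1 `CC(C(=O)NCc1ccc(C(F)(F)F)nc1-c1ccccc1)c1ccc(NS(C)(=O)=O)c(F)c1` gives 6.4 nM. Compound 2 `CC(C(=O)NCc1ccc(C(F)(F)F)nc1-c1ccc(Cl)cc1)c1ccc(NS(C)(=O)=O)c(F)c1` gives 0.7 nM, and compound 3 `CC(C(=O)NCc1ccc(C(F)(F)F)nc1-c1ccc(C(C)(C)C)cc1)c1ccc(NS(C)(=O)=O)c(F)c1` gives 0.5 nM. Compound 3 holds the lowest number of the three; its gap to compound 2 is within the scatter, while the step of a 13-fold lower number from compound 1 to compound 3 (1.11 log units; beyond the scatter) is beyond it, as is a 9.1-fold lower number from compound 1 to compound 2 (0.96 log units; beyond the scatter). The step of a 1.4-fold lower number from compound 2 to compound 3 (0.15 log units; within the scatter) is within the scatter, so compound 2 and compound 3 cannot be ranked against each other.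

Compound 4 `CC(C(=O)NCc1ccc(C(F)(F)F)nc1-c1ccc(Cl)c(Cl)c1)c1ccc(NS(C)(=O)=O)c(F)c1` is not yet measured. Relative to compound 3 the change is 3,4-dichlorophenyl in place of 4-(tert-butyl)phenyl on an aromatic carbon. Both measured substitutions on that phenyl ring, chloro or tert-butyl in place of hydrogen, lowered the number strongly, and exchanging one for the other changed little. Compound 4 keeps a chloro at the position that in compound 2 already gave a low number and adds a second one. The expectation is that compound 4 stays in the same low range as compound 2 and compound 3, with a step of a 1.2-fold higher number from compound 3 to compound 4 (0.08 log units; within the scatter) expected to be within the scatter. Compound 4 is therefore estimated at 0.6 nM in this assay, with a range from 0.2 nM to 2 nM.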

Compound 4, inhibition constant: 0.9 nM
Compound 4: middle estimate off by 1.5-fold (0.18 log units), on the low side, and the stated range covers the measured number.
By their numbers in this assay, from the lowest: compounds 3, 2 and 4 (each within the scatter of the next); then compound 1.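

Adding a second chloro to the pendant phenyl of compound 2 gives no readable change in this assay (a 1.3-fold higher number from compound 2 to compound 4 (0.11 log units; within the scatter)), and exchanging 4-(tert-butyl)phenyl for 3,4-dichlorophenyl is likewise within the scatter (a 1.8-fold higher number from compound 3 to compound 4 (0.26 log units; within the scatter)). Compound 4 keeps its distance from the unsubstituted phenyl of compound 1 (a 7.1-fold lower number from compound 1 to compound 4 (0.85 log units; beyond the scatter)), so this position now holds three substituted phenyl groups, of different atoms and sizes, that cannot be ranked against one another but all sit beyond the scatter from plain phenyl. The data shown give no reason for this flat response at the low end of the series, and no measurement explains why the three groups read alike.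

Still open is whether the low range survives on this phenyl ring with a group of a different kind, such as a methoxy, an amine or a carboxylic acid, since the three substituents shown are chloro and tert-butyl alone or a pair of chloros. With the values of compounds 2, 3 and 4 this close together, only a group that moves the number beyond the scatter would show what this position demands.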